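This account rests on a few compounds, and the source may have more. Where it says the series, first, only, none or still open, it means among the compounds named here.

Measured so far:
compound 1 `O=S(=O)(NCCCNCc1ccccc1Cl)c1cc(C(F)(F)F)cc(C(F)(F)F)c1`: 15000 nM
compound 2 `COc1ccc(CNCCCNS(=O)(=O)c2cc(C(F)(F)F)cc(C(F)(F)F)c2)cc1OC`: 18000 nM
compound 3 `O=S(=O)(NCCCNCc1ccccc1)c1cc(C(F)(F)F)cc(C(F)(F)F)c1`: 16000 nM

All three share the same core and differ only in the aromatic ring carried on a saturated chain carbon bound to an amine nitrogen. In a functional assay on PANC-1 cells (Homo sapiens) for inhibition, read by MTT assay, with a stated time of 72 h (on this read-out higher numbers stand for weaker inhibition of growth and lower numbers for stronger inhibition of growth), compound 1 gives 15000 nM. Compound 3 and compound 2 sit so close to it that none of the three can be told apart: the steps of a 1.1-fold higher number from compound 1 to compound 3 (0.03 log units; within the scatter) and a 1.2-fold higher number from compound 1 to compound 2 (0.08 log units; within the scatter) are both within the scatter, as is a 1.1-fold lower number from compound 2 to compound 3 (0.05 log units; within the scatter).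

Compound 4 `COc1ccc(CNCCCNS(=O)(=O)c2cc(C(F)(F)F)cc(C(F)(F)F)c2)cc1` has not yet been measured. It differs from compound 1 in one place: 4-methoxyphenyl in place of 2-chlorophenyl on a saturated chain carbon bound to an amine nitrogen. The closest guide is the step to compound 2, where a 3,4-dimethoxyphenyl replaced the same 2-chlorophenyl, and that step a 1.2-fold higher number from compound 1 to compound 2 (0.08 log units; within the scatter) was within the scatter. Removing the chloro altogether, as in compound 3, likewise moved nothing beyond the scatter. Taking these together, no step beyond the scatter is expected for compound 4 in this assay, and the estimated step of a 1.1-fold higher number from compound 1 to compound 4 (0.03 log units; within the scatter) is meant to reflect that. Compound 4 is therefore expected to give about 16000 nM, within a range from 8000 nM to 32000 nM.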

Compound 4, concentration for 50% growth inhibition: 11000 nM
Compound 4: middle estimate off by 1.5-fold (0.16 log units), on the high side, and the stated range covers the measured number.
By their numbers in this assay, from the lowest: compounds 4, 1, 3 and 2 (each within the scatter of the next).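

In this assay, the place on a saturated chain carbon bound to an amine nitrogen now accepts a 4-methoxyphenyl as readily as a 2-chlorophenyl, with a 1.4-fold lower number from compound 1 to compound 4 (0.13 log units; within the scatter). The methoxy steps can now be read directly: adding a methoxy to the plain phenyl gives a 1.5-fold lower number from compound 3 to compound 4 (0.16 log units; within the scatter), while the further methoxy of the 3,4-dimethoxyphenyl, read in reverse as hydrogen in place of methoxy, gives a 1.6-fold lower number from compound 2 to compound 4 (0.21 log units; within the scatter), so even this largest step among the four compounds does not leave the scatter. No measurement at hand offers an explanation for how little these ring changes matter.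

Every ring shown at this place is a six-membered aromatic ring of carbon only, so it remains open whether a pyridine, a saturated cyclohexyl group or a simple alkyl group would move the number beyond the scatter. All four compounds also share the same core, which leaves open what a longer chain or a carboxylic acid on that core would do to growth inhibition.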